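This account rests on a few compounds, and the source may have more. Where it says the series, first, only, none or still open, it means among the compounds named here.

In an assay on isolated protein for inhibition of myosin-2 (Bos taurus), read by spectrophotometry, with a stated time of 24 min (on this read-out lower numbers stand for stronger inhibition and higher numbers for weaker inhibition), three compounds have been measured, and none gave a number. Compound 1 `CCC/N=C(\C)c1c(O)c2ccccc2[nH]c1=O` reaches only a limit of this assay, and in this assay compound 1 gives >= 100000 nM. Compound 3 `C/C(=N\CC(C)C)c1c(O)c2ccccc2[nH]c1=O` also stops at a limit, so that in this assay compound 3 gives >= 100000 nM. Compound 2 `CCC/C(=N\Cc1ccccc1)c1c(O)c2ccccc2oc1=O` likewise returns a limit, and in this assay compound 2 gives >= 100000 nM. The change from compound 3 to compound 1 is hydrogen in place of methyl on a saturated chain carbon bound to two saturated chain carbons; the step it made, a step that the two limits leave unreadable from compound 3 to compound 1, cannot be sized, because the limit of >= 100000 nM in this assay, at which 3 of the 3 values shown sit, covers both ends of it. Compound 4 `CC/C(=N\Cc1ccccc1)c1c(O)c2ccccc2oc1=O` has not yet been measured. It differs from compound 2 by hydrogen in place of methyl on a saturated chain carbon, two bonds along the chain from a carbon with a double bond to nitrogen, the same kind of change as that from compound 3 to compound 1, though its place is a saturated chain carbon two bonds along the chain from a carbon with a double bond to nitrogen rather than one bound to two saturated chain carbons. The difference between the two cores is not broken down here. Because the limit of >= 100000 nM in this assay, at which 3 of the 3 values shown sit, is where compound 2 sits, the step to compound 4 is expected to be a number no higher from compound 2 to compound 4 (the limit leaves the size open). Compound 4 is therefore estimated at 100000 nM, between 30000 nM and 300000 nM, most probably as another limit.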

Compound 4, half-maximal inhibitory concentration: >= 100000 nM
Compound 4 was reported as a limit; the forecaster's own chance of this, stated with the estimate: 85%; the middle value sits exactly at the limit.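

In this assay compound 4 gives >= 100000 nM, which is a limit and not a number. Compound 2 also stops at a limit, so no new step can be read between compound 2 and compound 4: the limit of >= 100000 nM in this assay, at which 4 of the 4 values shown sit.

The compounds shown leave open what number any of them would give in this assay, and whether any change would bring one.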